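The source may hold more compounds than are shown below. What is called first, only, known or untested is meant among the compounds shown, and "the series" means these compounds.

Of the compounds shown here, three that share one core have been tested in a functional assay on the whole organism for inhibition, with Rattus norvegicus as the target, read by cytopathic effect and paw edema, at a dose of 100 mg/kg by the oral route; on this read-out lower numbers stand for less inhibition and higher numbers for more inhibition at the one dose given (going by the name of the read-out). In this assay compound 1 `COc1ccc(NC(=O)c2c(O)c3cccnc3n(-c3ccccc3)c2=O)cc1` gives -1.9%. Compound 2 `Nc1ccc(NC(=O)c2c(O)c3cccnc3n(-c3ccccc3)c2=O)cc1` gives 0%. Compound 3 `O=C(Nc1cccc([N+](=O)[O-])c1)c1c(O)c2cccnc2n(-c2ccccc2)c1=O` gives 7.4%. Compound 3 thus holds the highest of the three numbers, yet its gaps to the other two lie within the scatter, so the three numbers count as level. The change from compound 3 to compound 4 `O=C(NCc1ccncc1)c1c(O)c2cccnc2n(-c2ccccc2)c1=O` is (pyridin-4-yl)methyl in place of 3-nitrophenyl on an amide-type nitrogen. Two measured steps altered the same group on the amide-type nitrogen: a number 9.3 percentage points higher from compound 1 to compound 3 (within the scatter) and a number 7.4 percentage points higher from compound 2 to compound 3 (within the scatter), both within the scatter. The step of a number 1.9 percentage points higher from compound 1 to compound 2 (within the scatter) altered a group that compound 4 no longer carries. Since every measured exchange of the group on the amide-type nitrogen left the read-out within the scatter, the step of a number 4.4 percentage points lower from compound 3 to compound 4 (within the scatter) is expected to be of similar size, in no clear direction. Compound 4 is therefore estimated at 3%, within -10% to 16%.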

Compound 4, a percentage reported as inhibition, in the whole organism at one dose (the size of the read-out at that dose, not a potency): 15.4%
Compound 4: middle estimate off by 12.4 percentage points, on the low side; measured number inside the range.
By their numbers in this assay, from the lowest: compounds 1, 2, 3 and 4 (each within the scatter of the next, the first and the last beyond it).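

In this assay, exchanging the group on the amide-type nitrogen now gives steps beyond the scatter: a number 15.4 percentage points higher from compound 2 to compound 4 (beyond the scatter) and a number 17.3 percentage points higher from compound 1 to compound 4 (beyond the scatter). Compound 3 goes against this picture, as the step of a number 8 percentage points higher from compound 3 to compound 4 (within the scatter) stays within the scatter, so (pyridin-4-yl)methyl stands apart from 4-aminophenyl and 4-methoxyphenyl but not from 3-nitrophenyl. No measurement at hand accounts for these differences.

(pyridin-4-yl)methyl brings both a ring with a hetero atom and a methylene link to the nitrogen, and the compounds shown cannot separate these two changes. As far as these compounds go, a benzyl group or a pyridin-4-yl group joined directly to the nitrogen would tell them apart, while a longer chain such as 2-(pyridin-4-yl)ethyl remains open as well.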